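Moving a hydroxyl around on a pyridine-like core

A few compounds are considered here, and "the series" means these few. Any claim that something is new, unique, unknown or untested is made for them only; others in the source may bear on it.

Of the compounds shown here, three have been measured in a functional assay on DU-145 cells (Homo sapiens) for inhibition; a lower number here means a stronger inhibitor, a higher number a weaker inhibitor. Compound 1, `Oc1cccc(-c2cc(-c3ccccc3C(F)(F)F)cc(-c3cccc(O)c3)n2)c1`, gives 2870 nM. Compound 2, `Oc1ccc(-c2cc(-c3ccccc3C(F)(F)F)cc(-c3cccc(O)c3)n2)cc1`, gives 2750 nM. The two differ only by the change (4-hydroxyphenyl in place of 3-hydroxyphenyl on an aromatic carbon), and the step of a 1.0-fold lower number from compound 1 to compound 2 (0.02 log units; within the scatter), so the two values are not distinguishable from each other.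

Compound 3, `Oc1cccc(-c2cc(-c3cccc(OC(F)(F)F)c3)cc(-c3cccc(O)c3)n2)c1`, gives only a limit of the assay, > 50000 nM, rather than a number. This is the same limit as the limit of > 50000 nM in this assay, at which 1 of the 3 values shown sits. How the core of compound 3 differs from the core of compound 1 is not broken down here.

Compound 4, `Oc1ccc(-c2cc(-c3cccc(OC(F)(F)F)c3)cc(-c3cccc(O)c3)n2)cc1`, has not yet been measured. It differs from compound 3 by 4-hydroxyphenyl in place of 3-hydroxyphenyl on an aromatic carbon. Among the compounds with values here, this is the same kind of change as the one from compound 1 to compound 2, though the surroundings are not identical: in the first pair the place is meta to a 2-(trifluoromethyl)phenyl group, in the second pair it is meta to a large group, and in both it is meta to a 3-hydroxyphenyl group.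

Since the earlier step left the value essentially unchanged, the step from compound 3 to compound 4 is expected to be small as well, at about a step that the limit leaves unreadable from compound 3 to compound 4, resting on the measured step of a 1.0-fold lower number from compound 1 to compound 2 (0.02 log units; within the scatter). Compound 4 is therefore estimated at 60000 nM, most likely again reported only as a limit, with a plausible range from 20000 nM to 200000 nM.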

Compound 4, half-maximal inhibitory concentration: 5670 nM
Compound 4: the middle estimate sits 11-fold (1.02 log units) above what was measured, and the stated range ends above it.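

On the second core, in this assay, the same swap of 3-hydroxyphenyl for 4-hydroxyphenyl gives an at least 8.8-fold lower number from compound 3 to compound 4 (0.94 log units; beyond the scatter). The change therefore does not carry over from one core to the other with the same size, since it made no readable difference on the first core but a clear one on the second: the same change on two cores in this assay, a 1.0-fold lower number (0.02 log units; within the scatter) from compound 1 to compound 2 and an at least 8.8-fold lower number (0.94 log units; beyond the scatter) from compound 3 to compound 4, at least 8.4-fold (0.92 log units) apart, beyond the scatter of two such steps

Compound 3 has only a limit of the assay, > 50000 nM, so the true size of its step remains unknown, and these four compounds do not show why the two cores respond differently.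

With only two cores shown, it remains open whether the swap would matter on a third core, and so whether either result is the more usual one in this series. On these data alone, it is also open what an amine or a carboxylic acid would do in place of the hydroxyl on the moved ring, on either core.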